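Extending the Piperazine Substituent in a Cytotoxicity Series

The source may hold more compounds than are shown below. What is called first, only, known or untested is meant among the compounds shown, and "the series" means these compounds.

Of the compounds shown here, three sharing one core have been tested in a functional assay on HT-29 cells (Homo sapiens) for cytotoxicity, read by MTT assay, with a stated time of 24 h, tested at 16 ug/mL; on this read-out higher numbers stand for a stronger effect at the one concentration tested and lower numbers for a weaker effect. Compound 1 `Cc1nnc(SCC(=O)Nc2ccc(-c3nc(-c4ccccc4)c(-c4ccccc4)n3C)cc2)s1` gives 83.3%. Compound 2 `Cn1ccnc1SCC(=O)Nc1ccc(-c2nc(-c3ccccc3)c(-c3ccccc3)n2C)cc1` gives 36.5%, and compound 3 `CCN1CCN(CC(=O)Nc2ccc(-c3nc(-c4ccccc4)c(-c4ccccc4)n3C)cc2)CC1` gives 28.4%. Compound 3 therefore stands lowest of the three, with compound 2 nearest to it and compound 1 furthest away. The two steps leading to it are a number 54.9 percentage points lower from compound 1 to compound 3 (beyond the scatter) and a number 8.1 percentage points lower from compound 2 to compound 3 (within the scatter).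

Compound 4 `Cn1c(-c2ccc(NC(=O)CN3CCN(Cc4ccccc4)CC3)cc2)nc(-c2ccccc2)c1-c1ccccc1` is the next compound to be measured in this assay. It differs from compound 3 in one place: phenyl in place of methyl on a saturated chain carbon bound to an amine nitrogen in a ring.

Going by the values given here, none of the measured steps touches this position; all three change the group that sits on the saturated chain carbon bound to the carbonyl carbon, not the substituent on the amine nitrogen in the ring. Among the compounds with values here, with no precedent of that kind, no step beyond the scatter is expected from compound 3 to compound 4, so the estimate is a number 6.6 percentage points higher from compound 3 to compound 4 (within the scatter). Compound 4 is thus estimated at 35%, with a range from 15% to 60%.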

Compound 4, a percentage reported as activity, at one concentration (the size of the read-out at that concentration, not a potency): 37%
For compound 4 the middle estimate is 2 percentage points below the measured one; measured number inside the range.
By their numbers in this assay, from the lowest: compounds 3, 2 and 4 (each within the scatter of the next); then compound 1.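

Going by these compounds alone, replacing methyl with phenyl on a saturated chain carbon bound to an amine nitrogen in a ring, the same difference as ethyl to benzyl, is the first change at this position in this assay, and the step is a number 8.6 percentage points higher from compound 3 to compound 4 (within the scatter) even though the group grows from one heavy atom to seven counted this way and gains a six-membered aromatic ring. Within this single pair, then, that added ring produces no difference that can be told apart from ordinary scatter. No measurement shown here bears on the reason for this result.

As far as these compounds go, a longer chain in place of the benzyl, or an amine or a carboxylic acid on its phenyl ring, remains open. From the compounds shown here alone, with one concentration tested, potency also remains unknown.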